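From a Diol Chain to a Cyclopentyl Ring on the Amide

This account rests on a few compounds, and the source may have more. Where it says the series, first, only, none or still open, it means among the compounds named here.

Compound 1 `N=c1oc2ccc(Br)cc2cc1C(=O)NCC(O)CO` carries a 2,3-dihydroxypropyl group on its amide nitrogen. Among the measured compounds shown here, in an assay on CHO cells for displacement of a labelled ligand from adenosine receptor A1 (Homo sapiens), read by scintillation counting, with a stated time of 60 min, tested at 10 uM (on this read-out higher numbers stand for more inhibition at the one concentration tested (going by the name of the read-out) and lower numbers for less inhibition), compound 1 gives 11%, the lower of the two numbers measured so far. For the measured compounds named here, the only other measured compound, compound 2 `COc1ccc(-n2cnc(C#N)c2NC(=O)c2cc3cccc(OC)c3oc2=N)cc1`, is built on a different core, and in this assay compound 2 gives 37%, a number that lies beyond the scatter above compound 1. Going by the values given here, compound 3 `N=c1oc2ccc(Br)cc2cc1C(=O)NC1CCCC1` keeps the core of compound 1 and changes only the group on the amide nitrogen: cyclopentyl in place of 2,3-dihydroxypropyl on an amide-type nitrogen No measured pair shows this change, so its effect cannot be read from the data. In this assay the step that this estimate means, a number 14 percentage points higher from compound 1 to compound 3 (beyond the scatter), is expected to be a modest rise, though it might well stay within the scatter. Compound 3 is therefore expected to give about 25% in this assay, within a range from 5% to 55%.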

Compound 3, a percentage reported as inhibition, at one concentration (the size of the read-out at that concentration, not a potency): 17%
Beside the measured number, compound 3's estimate is 8 percentage points above it; the range from low to high includes it.
By their numbers in this assay, from the lowest: compounds 1 and 3 (each within the scatter of the next); then compound 2.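

In this assay the replacement of 2,3-dihydroxypropyl by cyclopentyl on the amide-type nitrogen gives a number 6 percentage points higher from compound 1 to compound 3 (within the scatter), so this single pair does not separate the two groups. Among the compounds shown here, this is the first direct reading at this position: an open chain with hydrogen-bond donors and acceptors gives way to a ring of carbon only with neither, and the two numbers still cannot be told apart. Nothing in the data explains why these two different groups read alike.

On these data alone, it remains open whether any group on this nitrogen can lift the number beyond the scatter, for example a chain ending in an amine, one ending in a carboxylic acid, or a longer hydrocarbon chain. A single test concentration also leaves the potency of both compounds unknown.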